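This account rests on a few compounds, and the source may have more. Where it says the series, first, only, none or still open, it means among the compounds named here.

Of the compounds shown here, two sharing one core have been measured in a functional assay on CHOK cells for antagonist activity at growth hormone secretagogue receptor type 1 (Homo sapiens), read by calcium flux; on this read-out lower numbers stand for stronger inhibition and higher numbers for weaker inhibition. Compound 1 `CCc1nc(N)nc(N)c1-c1ccc(NCc2ccc([N+](=O)[O-])cc2)cc1` gives 23 nM, and compound 2 `CCc1nc(N)nc(N)c1-c1ccc(NCc2ccc(C(C)=O)cc2)cc1` gives 110 nM. In this assay compound 2 stands highest of the two numbers, with compound 1 the nearest, the step being a 4.8-fold higher number from compound 1 to compound 2 (0.68 log units; beyond the scatter). Compound 3 `CCc1nc(N)nc(N)c1-c1ccc(NCc2ccnc(Cl)c2)cc1` differs from compound 2 by 2-chloropyridin-4-yl in place of 4-acetylphenyl on a saturated chain carbon bound to a nitrogen on an aromatic ring. Among the compounds with values here, no measured step covers this exchange of the whole aromatic group; the only known step concerns a substituent on that ring. For compound 3 the estimated step is a 1.1-fold lower number from compound 2 to compound 3 (0.04 log units; within the scatter). Compound 3 is therefore expected near 100 nM, between 30 nM and 350 nM.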

Compound 3, half-maximal inhibitory concentration: 220 nM
For compound 3 the middle estimate is 2.2-fold (0.34 log units) below the measured one; low and high end bracket the measured number.
By their numbers in this assay, from the lowest: compound 1; then compounds 2 and 3 (each within the scatter of the next).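

In this assay, the exchange of the whole aromatic group on a saturated chain carbon bound to a nitrogen on an aromatic ring gives a 2.0-fold higher number from compound 2 to compound 3 (0.30 log units; within the scatter), so a ring with a hetero atom can stand in for the carbon-only ring of compound 2 with no change beyond the scatter. Against 4-nitrophenyl the same group gives a 9.6-fold higher number from compound 1 to compound 3 (0.98 log units; beyond the scatter), which leaves compound 1 with the lowest number of the three. Nothing measured here explains these numbers.

On these data alone, it remains open how an amine or a methoxy group in place of the chlorine of 2-chloropyridin-4-yl would read. Also open, as far as these compounds go, is whether a nitro group on that same ring would bring the number down to that of compound 1.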